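Swapping a thioether chain for 2-fluorophenyl in a cytotoxicity series

The compounds below may be only part of what the source reports. "The series", "measured", "known", "first", "only" and "open" are said of these compounds alone.

In an ADME assay on MT4 cells (Homo sapiens) for cytotoxicity (a higher number here means that more compound is tolerated, a lower number that less compound is tolerated), compound 3 `CSCCCNC(=S)Nc1cccc(C(F)(F)F)c1` gives 43000 nM, the higher of the two exact numbers, and compound 1 `FC(F)(F)c1cccc(NC(=S)Nc2ccc(I)cc2)c1` gives 10000 nM. Compound 2 `CCNC(=S)Nc1cccc(C(F)(F)F)c1` gives > 100000 nM, which is a limit of the assay and not a number.

Compound 4 `Fc1ccccc1NC(=S)Nc1cccc(C(F)(F)F)c1` carries 2-fluorophenyl in place of 3-(methylsulfanyl)propyl on an amide-type nitrogen. For the measured compounds named here, compound 1 is the only measured compound with an aromatic ring at that place, so two measured steps bear most directly on the change. One is a 4.3-fold higher number from compound 1 to compound 3 (0.63 log units; beyond the scatter), and the other is an at least 10-fold higher number from compound 1 to compound 2 (1.00 log units; beyond the scatter). Both lead away from the ring, whereas the new change leads back to one.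

Read in reverse, the step of a 4.3-fold higher number from compound 1 to compound 3 (0.63 log units; beyond the scatter) leads one to expect a lower number in this assay, of modest size and beyond the scatter. No measurement covers the exchange of one ring substituent for another. The expected change is a 2.9-fold lower number from compound 3 to compound 4 (0.46 log units; beyond the scatter). Compound 4 is estimated at 15000 nM, with an expected range of 6000 nM to 40000 nM.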

Compound 4, half-maximal cytotoxic concentration: 47000 nM
For compound 4 the middle estimate is 3.1-fold (0.50 log units) below the measured one; the whole stated range lies below it.
By their numbers in this assay, from the lowest: compound 1; then compounds 3 and 4 (each within the scatter of the next). At a limit, above all of these: compound 2.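

With 2-fluorophenyl on the amide-type nitrogen, an aromatic ring at this place no longer goes with the lowest number in this assay: exchanging the 3-(methylsulfanyl)propyl chain for it gives a 1.1-fold higher number from compound 3 to compound 4 (0.04 log units; within the scatter) and so does not separate ring from chain here. Exchanging one ring for the other gives a 4.7-fold higher number from compound 1 to compound 4 (0.67 log units; beyond the scatter) and shows that the low number of compound 1 goes with 4-iodophenyl, not with every aromatic ring at this place. Ethyl remains apart, with an at least 2.1-fold lower number from compound 2 to compound 4 (0.32 log units; beyond the scatter) and with compound 2 standing as a limit of the assay, not a number: the limit of > 100000 nM in this assay, at which 1 of the 4 values shown sits.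

The compounds shown leave open where phenyl without a substituent would fall between the two rings. They also leave open how a chain ending in an amine or a carboxylic acid would compare with 3-(methylsulfanyl)propyl.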